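Piperidinyl for diethylaminoethyl on the ring amine of compound 1

This account rests on a few compounds, and the source may have more. Where it says the series, first, only, none or still open, it means among the compounds named here.

Compound 1 `CCN(CC)CCN1CCN(C(=O)COCCN(C)S(=O)(=O)c2c(C)cc(OC)cc2C)CC1` gives 7.8 in a functional assay on Umbilical vein for antagonist activity at B1 bradykinin receptor (Homo sapiens), using Schild analysis, with a stated time of 30 min; a higher number here means a more potent compound, by a factor of ten per unit of this negative logarithm, a lower number a less potent compound. Among the three measured compounds it sits below compound 2 `COc1ccc(S(=O)(=O)N(C)CCOCC(=O)N(C)Cc2ccc(C3=NCCN3)cc2)c(C)c1`, which gives 8.6 and is beyond the scatter from it, and within the scatter of compound 3 `CN(Cc1ccc(C2=NCCN2)cc1)C(=O)COCCN(C)S(=O)(=O)c1c(F)cccc1F`, which gives 7.6. Going by the values given here, the only measured step, a number 1.00 log units lower from compound 2 to compound 3 (beyond the scatter), concerns a change on the sulfonyl sulfur; it does not touch the amine nitrogen in the ring that distinguishes compound 1 from compound 4.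

Compound 4 `CCN1CCC(N2CCN(C(=O)COCCN(C)S(=O)(=O)c3c(C)cc(OC)cc3C)CC2)CC1` differs from compound 1 by 1-ethylpiperidin-4-yl in place of 2-(diethylamino)ethyl on an amine nitrogen in a ring. Both groups carry a single tertiary amine and no donors, so the change is a redrawing of the side chain rather than a change in its count of polar atoms. Among the compounds with values here, no measured step bears on this position; the expectation is therefore no step beyond the scatter, with a wide range to reflect the lack of precedent. Compound 4 is estimated at 7.8, between 7.2 and 8.4, a step of no change at the digits printed from compound 1 to compound 4 (within the scatter).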

Compound 4, negative logarithm of the antagonist equilibrium constant: 8.8
Compound 4: middle estimate off by 1.00 log units, on the low side, and the stated range ends below it.
By their numbers in this assay, from the lowest: compounds 3 and 1 (each within the scatter of the next); then compounds 2 and 4 (each within the scatter of the next).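

In this assay the side chain on the ring amine proves to be a second place where the number moves, alongside the sulfonyl sulfur: the step is a number 1.00 log units higher from compound 1 to compound 4 (beyond the scatter), with 1-ethylpiperidin-4-yl in place of 2-(diethylamino)ethyl. The two groups have the same counts of hydrogen-bond donors and acceptors and no net charge, so those counts do not separate them; they differ in the six-membered non-aromatic ring and in the size of the group. No measurement at hand gives a reason for the step.

From the compounds shown here alone, whether the ring or the added carbon carries the step remains open, and 1-methylpiperidin-4-yl on the same ring amine would help separate the two. Also open, going by these compounds, is whether the step holds with the 2,6-difluorophenyl group on the sulfonyl sulfur.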